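Acetylation of the core amine in an amide and a urea pair

This account rests on a few compounds, and the source may have more. Where it says the series, first, only, none or still open, it means among the compounds named here.

Measured so far, in a functional assay on Malme-3M cells (Homo sapiens) for antiproliferative activity, read by sulforhodamine B assay, with a stated time of 48 h; on this read-out lower numbers stand for stronger inhibition and higher numbers for weaker inhibition:
compound 1, `Nc1cccc2c(-c3cccc(NC(=O)c4ccc5c(c4)OCCO5)c3)ccnc12`, gives > 20000 nM, a limit of the assay and not a number.
compound 2, `CC(=O)Nc1cccc2c(-c3cccc(NC(=O)c4ccc5c(c4)OCCO5)c3)ccnc12`, gives > 20000 nM, again a limit and not a number.
compound 3, `Nc1cccc2c(-c3cccc(NC(=O)Nc4cc(C(F)(F)F)cc(C(F)(F)F)c4)c3)ccnc12`, gives 1500 nM.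

Compound 2 differs from compound 1 by acetyl in place of hydrogen on a nitrogen on an aromatic ring. The step that the two limits leave unreadable from compound 1 to compound 2 is not readable because the limit of > 20000 nM in this assay, at which 2 of the 3 values shown sit, holds both of its ends. Compound 3 carries a different amide-side group, and the difference between its core and that of compound 1 is not broken down here.

Compound 4, `CC(=O)Nc1cccc2c(-c3cccc(NC(=O)Nc4cc(C(F)(F)F)cc(C(F)(F)F)c4)c3)ccnc12`, is not yet measured. It differs from compound 3 by acetyl in place of hydrogen on a nitrogen on an aromatic ring, the same change as from compound 1 to compound 2, at the same place. As that earlier step cannot be sized, the expectation for compound 4 rests only on compound 3 and its value 1500 nM, with a step of a 1.7-fold higher number from compound 3 to compound 4 (0.22 log units; within the scatter) expected in this assay and wide uncertainty on either side. For compound 4 the estimate is therefore 2500 nM, with a range from 800 nM to 9000 nM.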

Compound 4, half-maximal inhibitory concentration: 18100 nM
Beside the measured number, compound 4's estimate is 7.2-fold (0.86 log units) below it, and the stated range ends below it.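

In this assay, acetyl in place of hydrogen on a nitrogen on an aromatic ring gives a 12-fold higher number from compound 3 to compound 4 (1.08 log units; beyond the scatter), so in the urea pair the change clearly weakens inhibition. In the amide pair, compound 1 and compound 2 each sit at a limit of the assay and not at a number, so the same change cannot be read there: the limit of > 20000 nM in this assay, at which 2 of the 4 values shown sit. The step therefore rests on a single pair; it gives the direction and size of the change on the core of compound 3, but it does not show that the change carries over from one core to another, and it gives no reason for the loss.

Still open, from the compounds shown here alone, is whether methyl or methanesulfonyl on that same nitrogen would give a step like that of acetyl. Also open, going by these compounds, is whether the acetyl step would hold on a urea with a chlorophenyl group in place of the phenyl ring bearing trifluoromethyl groups.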